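A few compounds are considered here, and "the series" means these few. Any claim that something is new, unique, unknown or untested is made for them only; others in the source may bear on it.

Compound 2 `Clc1ccc(-c2cc(-c3cccnc3)nc(-c3cccs3)c2)o1` gives 22300 nM in a functional assay on K562 cells (Homo sapiens) for cytotoxicity, in the presence of a further agent that is not named here; a lower number here means a stronger inhibitor, a higher number a weaker inhibitor. Among the three measured compounds it stands highest, yet compound 1 `Clc1ccc(-c2cc(-c3cccnc3)nc(-c3ccsc3)c2)o1` with 21700 nM and compound 3 `Cc1ccccc1-c1cc(-c2ccc(Cl)o2)cc(-c2ccsc2)n1` with 18400 nM both lie within the usual scatter of it, so the three cannot be told apart. Compound 4 `Clc1ccc(-c2cc(-c3ccco3)nc(-c3cccs3)c2)o1` differs from compound 2 in one place: furan-2-yl in place of pyridin-3-yl on an aromatic carbon. Neither measured step repeats this exact change. The step of a 1.0-fold higher number from compound 1 to compound 2 (0.01 log units; within the scatter) concerns the thiophene group, and the step of a 1.2-fold lower number from compound 1 to compound 3 (0.07 log units; within the scatter) also replaced pyridin-3-yl on an aromatic carbon, with no change beyond the scatter. On that basis the step of a 1.0-fold lower number from compound 2 to compound 4 (0.01 log units; within the scatter) is expected to stay within the scatter. For compound 4 the expected value in this assay is 22000 nM, with a range from 11000 nM to 44000 nM.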

Compound 4, half-maximal inhibitory concentration: 16000 nM
Beside the measured number, compound 4's estimate is 1.4-fold (0.14 log units) above it, within the range that was stated.
By their numbers in this assay, from the lowest: compounds 4, 3, 1 and 2 (each within the scatter of the next).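

At the position next to the ring nitrogen, furan-2-yl in place of pyridin-3-yl gives a 1.4-fold lower number from compound 2 to compound 4 (0.14 log units; within the scatter) in this assay. The earlier change at this position put in 2-methylphenyl alongside thiophen-3-yl, whereas this one shows that a five-membered ring with oxygen, alongside thiophen-2-yl, also stays within the scatter. No measurement shown here offers an explanation for this result.

All the groups shown at this position are aromatic rings. As far as these compounds go, whether a non-aromatic group there, such as an aminomethyl group or a carboxylic acid, would shift the number beyond the scatter remains open.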